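From methoxy to chloro and trifluoromethyl: a half-life estimate

The source may report more compounds than this note shows. Statements on the series, on what has been measured and on what is new or still open speak of the compounds shown alone.

Compound 1 `CCS(=O)(=O)c1ccc(CNC(=O)c2ccc3c(c2)cc(Cc2ccc(Cl)cc2C(F)(F)F)n3C2CC2)cc1`: 2.32 h
Compound 2 `CCS(=O)(=O)c1ccc(CNC(=O)c2ccc3c(c2)cc(Cc2ccccc2C(F)(F)F)n3C(C)C)cc1`: 0.65 h
Compound 3 `CCS(=O)(=O)c1ccc(CNC(=O)c2ccc3c(c2)cc(Cc2ccccc2OC)n3C(C)C)cc1`: 0.217 h

In an ADME assay on microsomes from liver (Homo sapiens) for metabolic stability (a higher number here means that the compound lasts longer, a lower number that the compound disappears faster), compound 3 stands lowest of the three, at 0.217 h, and the other two numbers both lie clearly above it. The next compound to be measured is compound 4 `CCS(=O)(=O)c1ccc(CNC(=O)c2ccc3c(c2)cc(Cc2ccc(Cl)cc2C(F)(F)F)n3C(C)C)cc1`, which differs from compound 3 at one place: 4-chloro-2-(trifluoromethyl)phenyl in place of 2-methoxyphenyl on a saturated chain carbon bound to an aromatic carbon. The swap sits on a saturated chain carbon bound to an aromatic carbon, and 2-methoxybenzyl gives way to 4-chloro-2-(trifluoromethyl)benzyl.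

Going by the values given here, one measured step bears on this: a 3.0-fold lower number from compound 2 to compound 3 (0.48 log units; beyond the scatter), with methoxy in place of trifluoromethyl. Read in reverse, that step points upward for compound 4, which carries trifluoromethyl where compound 3 has methoxy. Among the compounds with values here, compound 4 also carries a chloro group that compound 2 lacks, and no measured step isolates that addition. Compound 1 has the same benzyl group as compound 4, but cyclopropyl where compound 4 has isopropyl. Compound 1 at 2.32 h is therefore only a loose guide to how high the number might go.

A rise somewhat larger than the measured step is expected, and the estimated change is a 5.5-fold higher number from compound 3 to compound 4 (0.74 log units; beyond the scatter). For compound 4 the expected half-life is 1.2 h, with an estimated range from 0.6 h to 2.6 h.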

Compound 4, half-life: 3.03 h
Compound 4: the middle estimate sits 2.5-fold (0.40 log units) below what was measured; the measured number lies above the stated range.
By their numbers in this assay, from the lowest: compound 3; then compound 2; then compounds 1 and 4 (each within the scatter of the next).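

Going by these compounds alone, the chloro group now has a measured effect of its own in this assay: with chloro in place of hydrogen on an aromatic carbon, the result is a 4.7-fold higher number from compound 2 to compound 4 (0.67 log units; beyond the scatter) and this addition is the part that no earlier pair could isolate. The full exchange of 2-methoxyphenyl for 4-chloro-2-(trifluoromethyl)phenyl on a saturated chain carbon bound to an aromatic carbon gives a 14-fold higher number from compound 3 to compound 4 (1.14 log units; beyond the scatter) and can now be read as two single changes, methoxy to trifluoromethyl and hydrogen to chloro, each with a step beyond the scatter. On the aromatic nitrogen, with this benzyl group in place, isopropyl and cyclopropyl cannot be told apart in this measurement, since a 1.3-fold higher number from compound 1 to compound 4 (0.12 log units; within the scatter) stays small enough to count as repeat variation.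

Nothing shown here explains why these changes alter the half-life. Still open, going by these compounds, is whether a nitrile or a carboxylic acid in the place of the chloro group would give a similar half-life, and whether the chloro step would be repeated with cyclopropyl on the aromatic nitrogen.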